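A few compounds are considered here, and "the series" means these few. Any claim that something is new, unique, unknown or untested is made for them only; others in the source may bear on it.

Measured so far:
compound 1 `C=C(Br)C(=O)Nc1cccc(/C=C2\SC(=O)N(Cc3ccc(C)cc3)C2=O)c1`: 1200 nM
compound 2 `C=C(Br)C(=O)Nc1ccc(/C=C2\SC(=O)N(Cc3ccc(C)cc3)C2=O)cc1`: 8900 nM
compound 3 `Nc1ccc(/C=C2\SC(=O)N(Cc3cccc(F)c3)C2=O)cc1`: 250000 nM

In a functional assay on HeLa cells (Homo sapiens) for cytotoxicity, read by cell counting, with a stated time of 4 days (a higher number here means a weaker inhibitor, a lower number a stronger inhibitor), compound 2 gives 8900 nM, the second highest of these three numbers. Compound 1 gives 1200 nM, a lower number, and that gap lies beyond the scatter. Compound 3 gives 250000 nM, a far higher number, again beyond the scatter. Compound 4 `C=C(Br)C(=O)Nc1ccc(/C=C2\SC(=O)N(C)C2=O)cc1` has not yet been measured. It differs from compound 2 in one place: hydrogen in place of 4-methylphenyl on a saturated chain carbon bound to an amide-type nitrogen in a ring. A whole six-membered aromatic ring of carbon only leaves, and a single hydrogen enters. Within the data shown here, no measured pair shows a change of this kind, so its size is uncertain. A weakening is expected, beyond the scatter yet well short of the distance to compound 3. Compound 4 is expected to give about 20000 nM in this assay, between 5000 nM and 80000 nM, an expected step of a 2.2-fold higher number from compound 2 to compound 4 (0.35 log units; beyond the scatter).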

Compound 4, half-maximal inhibitory concentration: 870 nM
Beside the measured number, compound 4's estimate is 23-fold (1.36 log units) above it, and the stated range ends above it.
By their numbers in this assay, from the lowest: compounds 4 and 1 (each within the scatter of the next); then compound 2; then compound 3.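

Replacing 4-methylphenyl with hydrogen on a saturated chain carbon bound to an amide-type nitrogen in a ring gives, in this assay, a 10-fold lower number from compound 2 to compound 4 (1.01 log units; beyond the scatter). At this position, then, the whole aromatic ring can leave without any loss, and the number falls rather than rises. No measurement on hand explains why the smaller group gives the lower number. Still open, going by these compounds, is how a longer chain, such as propyl, or a carboxylic acid at the end of that chain would read in this assay. The shift could continue, stop or reverse.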